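A few compounds are considered here, and "the series" means these few. Any claim that something is new, unique, unknown or untested is made for them only; others in the source may bear on it.

Values so far in a functional assay on 2008 cells (Homo sapiens) for cytotoxicity, read by MTT assay, with a stated time of 68 h; a higher number here means a weaker inhibitor, a lower number a stronger inhibitor
compound 1 (`O=C(/C=C/c1cccc(OCc2ccccc2)c1)c1ccc([N+](=O)[O-])cc1`) gives 49000 nM
compound 2 (`O=C(/C=C/c1cccc(OCc2ccccc2)c1)c1ccc(Cl)cc1Cl`) gives 5200 nM
compound 3 (`O=C(/C=C/c1cccc(OCc2ccccc2)c1)c1ccc(Cl)cc1`) gives 20000 nM

Compound 3 holds the middle place of the three, with a 2.5-fold lower number from compound 1 to compound 3 (0.39 log units; beyond the scatter) on one side and a 3.8-fold higher number from compound 2 to compound 3 (0.59 log units; beyond the scatter) on the other. The next analogue is compound 4 (`O=C(/C=C/c1cccc(OCc2ccccc2)c1)c1ccccc1Br`), which differs from compound 3 by 2-bromophenyl in place of 4-chlorophenyl on a carbonyl carbon in the group on the carbonyl carbon, that is, 2-bromophenyl in place of 4-chlorophenyl.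

Within the data shown here, no bromo compound has been measured, so the evidence is indirect. The most relevant measured change is a 3.8-fold higher number from compound 2 to compound 3 (0.59 log units; beyond the scatter) in this assay, where hydrogen replaces chloro on an aromatic carbon. Among the measured compounds shown here, compound 2 carries 2,4-dichlorophenyl, the only measured group with a halogen numbered 2, as in 2-bromophenyl. The wider a 9.4-fold lower number from compound 1 to compound 2 (0.97 log units; beyond the scatter) spans the whole measured range, but it starts from the 4-nitrophenyl group and says less about this change.

Compound 4 keeps one halogen and has no group numbered 4, so only part of the gain seen for compound 2 is expected. The expected outcome is a small move to a lower number, a 1.7-fold lower number from compound 3 to compound 4 (0.22 log units; within the scatter) in the estimate. For compound 4 the estimated value is 12000 nM with an expected range from 4500 nM to 32000 nM in this read-out.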

Compound 4, half-maximal inhibitory concentration: 1200 nM
Compound 4: middle estimate off by 10-fold (1.00 log units), on the high side, and the stated range ends above it.
By their numbers in this assay, from the lowest: compound 4; then compound 2; then compound 3; then compound 1.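

In this assay, among these compounds, the move to 2-bromophenyl on the carbonyl carbon gives a 17-fold lower number from compound 3 to compound 4 (1.22 log units; beyond the scatter) and so shows that this group can shift the number far more than the chloro changes among the earlier compounds suggested. The single-halogen group also outdoes the 2,4-dichlorophenyl group, with a 4.3-fold lower number from compound 2 to compound 4 (0.64 log units; beyond the scatter) in this comparison, so a second halogen is not required for the lowest number in the series, and a 41-fold lower number from compound 1 to compound 4 (1.61 log units; beyond the scatter) in the comparison with the nitro compound makes compound 4 the strongest of the four, every step to it lying beyond the scatter. Nothing available explains the size of this gain.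

Compound 4 changes both the halogen and its numbered place in one step, so the compounds shown leave open which of the two carries the gain, a question that 2-chlorophenyl and 4-bromophenyl would separate. Also open, on these data alone, is whether a group without halogen, such as 2-methylphenyl or 2-methoxyphenyl, on the same carbonyl carbon would keep a number this low.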